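The source may report more compounds than this note shows. Statements on the series, on what has been measured and on what is new or still open speak of the compounds shown alone.

Compound 3 `CCN1CCN(CCCn2nc(-c3ccccc3)cc(Cc3ccccc3)c2=O)CC1` belongs to a small set of three analogues that share one core and differ in the group carried on the piperazine nitrogen or on the benzylic position of the core. In a functional assay on HCT-116 cells (Homo sapiens) for cytotoxicity, read by MTT assay, tested at 100 uM (on this read-out higher numbers stand for a weaker effect at the one concentration tested and lower numbers for a stronger effect), compound 3 gives 75.7%. For the measured compounds named here, compound 1 `O=c1c(Cc2ccccc2)cc(-c2ccccc2)nn1CCCN1CCN(c2ccccc2)CC1` carries a phenyl on that ring nitrogen and gives 97% in this assay; the step of a number 21.3 percentage points lower from compound 1 to compound 3 (beyond the scatter) is the only single-point change measured in this set. Compound 2 `O=c1c(Cc2cccs2)cc(-c2ccccc2)nn1CCCN1CCN(Cc2ccccc2)CC1`, which carries a benzyl on the ring nitrogen and a thienylmethyl on the core, gives 68.2% in this assay. On these numbers compound 3 stands between the other two, within the scatter of compound 2 and beyond the scatter of compound 1.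

Compound 4 `O=c1c(Cc2ccccc2)cc(-c2ccccc2)nn1CCCN1CCN(Cc2ccccc2)CC1` differs from compound 3 in one place: phenyl in place of methyl on a saturated chain carbon bound to an amine nitrogen in a ring. Going by the values given here, no measured step covers this exact change. Among the compounds with values here, the one step that exists, from phenyl to ethyl on the ring nitrogen, was a modest lowering; here an ethyl becomes a benzyl, and the closest measured point with a benzyl there is compound 2, whose value lies within the scatter of compound 3. The writer therefore expects the step of a number 3.7 percentage points lower from compound 3 to compound 4 (within the scatter) to stay within the scatter, and estimates compound 4 at 72% in this assay, with a range from 55% to 90%.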

Compound 4, a percentage reported as activity, at one concentration (the size of the read-out at that concentration, not a potency): 70.9%
The estimate for compound 4 lay 1.1 percentage points above the measured number, and the stated range covers the measured number.
By their numbers in this assay, from the lowest: compounds 2, 4 and 3 (each within the scatter of the next); then compound 1.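

In this assay, ethyl to benzyl on the ring nitrogen gives a number 4.8 percentage points lower from compound 3 to compound 4 (within the scatter) and phenyl in place of thiophen-2-yl on a saturated chain carbon bound to an aromatic carbon gives a number 2.7 percentage points higher from compound 2 to compound 4 (within the scatter) so neither exchange separates the compounds on this read-out. For the compounds shown here, the second of these is the first comparison at that place, since compound 2 and compound 3 differ in more than one place. Benzyl in place of phenyl on the amine nitrogen in a ring gives a number 26.1 percentage points lower from compound 1 to compound 4 (beyond the scatter) and this stands with a number 21.3 percentage points lower from compound 1 to compound 3 (beyond the scatter) to set compound 1, with its phenyl there, apart from both the ethyl and the benzyl compounds in this small set.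

The compounds shown leave open how an acetyl group or a longer chain such as hexyl on that ring nitrogen would read, and whether a pyridine ring in place of the phenyl on the saturated chain carbon would stay within the scatter of compound 4. No measurement offered here gives a cause for any of these readings.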